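A Triazole Aryl Exchange on Compound 1

A few compounds are considered here, and "the series" means these few. Any claim that something is new, unique, unknown or untested is made for them only; others in the source may bear on it.

Compound 1 `COc1ccc([C@@H]2C/C(=N/OCc3cn(-c4ccc(O)cc4)nn3)c3cc(CC=C(C)C)c(OC)cc3O2)cc1` – 64%
Compound 2 `COc1cc2c(cc1CC1OC1(C)C)C(=O)C[C@@H](c1ccc(O)cc1)O2` – 92%

Both compounds were tested in a functional assay on PC-3 cells (Homo sapiens) for inhibition, read by sulforhodamine B assay, with a stated time of 48 h, tested at 50 uM; a lower number here means less inhibition of growth, a higher number more inhibition of growth at the concentration tested. Compound 1, at 64%, stands lowest of the two, and the gap up to compound 2 lies beyond the usual scatter. The two differ in more than one place, so their gap says nothing about a single group.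

Compound 3 `COc1ccc([C@@H]2C/C(=N/OCc3cn(-c4ccc(Cl)cc4C)nn3)c3cc(CC=C(C)C)c(OC)cc3O2)cc1` keeps the core of compound 1 but carries 4-chloro-2-methylphenyl in place of 4-hydroxyphenyl on an aromatic nitrogen. Going by the values given here, no measured pair tests this exchange, so no direction can be firmly expected, and a change within the scatter of this assay seems most likely. The expected step is a number 4 percentage points lower from compound 1 to compound 3 (within the scatter). For compound 3 the estimated value is 60%, with an expected range from 35% to 85%.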

Compound 3, percent growth inhibition at one concentration: 49%
The estimate for compound 3 lay 11 percentage points above the measured number, and the stated range covers the measured number.
By their numbers in this assay, from the lowest: compound 3; then compound 1; then compound 2.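

Going by these compounds alone, the exchange of 4-hydroxyphenyl for 4-chloro-2-methylphenyl on the aromatic nitrogen gives the first reading at this position in this assay: a number 15 percentage points lower from compound 1 to compound 3 (beyond the scatter), so the aryl group at this place does affect growth inhibition at the concentration tested, though the step is modest. The step is one bundled change, in which the hydroxy group, counted as both hydrogen-bond donor and acceptor, leaves while a chlorine and a methyl group enter. Nothing shown accounts for the step. The compounds shown leave open which of these parts carries the step, since the hydroxy group, the chlorine and the methyl group never change alone. They also leave open how an amine or a carboxylic acid on this phenyl ring would read against the same core.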